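Removing the Methoxy Group from the Pendant Phenyl Ring

A few compounds are considered here, and "the series" means these few. Any claim that something is new, unique, unknown or untested is made for them only; others in the source may bear on it.

Three measured compounds share one core and differ at two places. Compound 1 `CC(C)c1cc2[nH]c(-c3ccc([N+](=O)[O-])cc3)cc(=O)n2n1` gives 25500 nM in a functional assay on U-251 cells (Homo sapiens) for cytotoxicity, read by resazurin assay, with a stated time of 48 h; on this read-out lower numbers stand for stronger inhibition and higher numbers for weaker inhibition. Compound 2 `COc1ccc(-c2cc(=O)n3nc(C(C)C)cc3[nH]2)cc1` gives 197000 nM, and compound 3 `COc1ccc(-c2cc(=O)n3nc(-c4ccccc4)cc3[nH]2)cc1` gives 13400 nM. Compound 3 thus carries the lowest number of the three, though compound 1 sits within the scatter of it; compound 2 stands clearly apart because a 15-fold lower number from compound 2 to compound 3 (1.17 log units; beyond the scatter).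

Compound 4 `O=c1cc(-c2ccccc2)[nH]c2cc(-c3ccccc3)nn12` differs from compound 3 in a single place: hydrogen in place of methoxy on an aromatic carbon. Within the data shown here, the only measured step at that aromatic carbon is a 7.7-fold higher number from compound 1 to compound 2 (0.89 log units; beyond the scatter), a modest change, and it compares two substituted rings rather than a bare one. Nothing measured here shows what a hydrogen at that carbon does, so the direction is open, and the size is expected to be modest rather than large. Compound 4 is therefore expected to give about 15000 nM, with a range from 5000 nM to 50000 nM. That estimate amounts to a step of a 1.1-fold higher number from compound 3 to compound 4 (0.05 log units; within the scatter).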

Compound 4, half-maximal inhibitory concentration: 77700 nM
Compound 4: the middle estimate sits 5.2-fold (0.71 log units) below what was measured, and the stated range ends below it.
By their numbers in this assay, from the lowest: compounds 3 and 1 (each within the scatter of the next); then compound 4; then compound 2.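

Within this assay, removing the methoxy group from compound 3 does not leave the number unchanged: the step is beyond the scatter (a 5.8-fold higher number from compound 3 to compound 4 (0.76 log units; beyond the scatter)). Among these compounds, this is the first direct comparison of a hydrogen with a substituent at this aromatic carbon, where the earlier step compared only nitro with methoxy, and on the isopropyl-bearing compounds. With the phenyl group at the other varied place, the 4-methoxyphenyl group gives the lower number and the plain phenyl the higher one, and nothing available accounts for this difference.

The compounds shown leave open whether the same change would go the same way with isopropyl at the other varied place, as compound 2 has no plain phenyl partner here. They also leave open how a hydroxyl, an amine or a fluorine at this aromatic carbon would compare with methoxy and hydrogen.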